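A few compounds are considered here, and "the series" means these few. Any claim that something is new, unique, unknown or untested is made for them only; others in the source may bear on it.

Measured so far in a functional assay on HT-29 cells (Homo sapiens) for cytotoxicity, read by MTT assay, with a stated time of 72 h; on this read-out higher numbers stand for weaker inhibition and lower numbers for stronger inhibition:
- compound 1 `COc1ccc(Nc2cc(Nc3ccc(Oc4ccncc4-c4cccnc4)c(F)c3)ncn2)cc1` gives 4110 nM
- compound 2 `Fc1ccc(Nc2cc(Nc3ccc(Oc4ccncc4-c4cccnc4)c(F)c3)ncn2)cc1` gives 330 nM
- compound 3 `Cn1c(=O)c(C(=O)Nc2ccc(Oc3ccncc3-c3cccnc3)c(F)c2)nn(-c2ccccc2F)c1=O` gives 2100 nM

Compound 3 stands second highest of the three numbers. Its nearest neighbour is compound 1, whose value sits within the scatter of that of compound 3; compound 2 lies furthest, with the lower number, a gap beyond the scatter.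

Compound 4 `COc1ccc(-n2nc(C(=O)Nc3ccc(Oc4ccncc4-c4cccnc4)c(F)c3)c(=O)n(C)c2=O)c(OC)c1` is not yet measured. It differs from compound 3 in one place: 2,4-dimethoxyphenyl in place of 2-fluorophenyl on an aromatic nitrogen. Within the data shown here, the only measured step that touches on this is a 12-fold lower number from compound 1 to compound 2 (1.10 log units; beyond the scatter), where fluoro replaced methoxy on an aromatic carbon and the number fell sharply. The present change runs the other way, fluoro leaving and two methoxy groups entering, though on a different core and on an aromatic nitrogen rather than a carbon, so it bears on the step only loosely. On that single precedent a higher number is expected for compound 4, of moderate size, with wide uncertainty.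

Compound 4 is therefore estimated at 4000 nM in this assay, within 1200 nM to 13000 nM. That estimate means a step of a 1.9-fold higher number from compound 3 to compound 4 (0.28 log units; within the scatter), expected rather than known.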

Compound 4, half-maximal inhibitory concentration: 890 nM
For compound 4 the middle estimate is 4.5-fold (0.65 log units) above the measured one; measured number below the stated range.
By their numbers in this assay, from the lowest: compound 2; then compound 4; then compounds 3 and 1 (each within the scatter of the next).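

In this assay, 2,4-dimethoxyphenyl in place of 2-fluorophenyl on the aromatic nitrogen gives a 2.4-fold lower number from compound 3 to compound 4 (0.37 log units; beyond the scatter) and so shows that this position accepts the two methoxy groups with no loss in the number. The direction runs against a 12-fold lower number from compound 1 to compound 2 (1.10 log units; beyond the scatter), where fluoro in place of methoxy on an aromatic carbon lowered the number, so that step, taken on a different core, does not carry over to this position. No measurement at hand accounts for the lower number of compound 4.

As far as these compounds go, the entering group carries both methoxy groups at once, and whether either one alone gives the same step remains open. Also open, from the compounds shown here alone, is how an amine or a carboxylic acid on this phenyl ring would read in this assay.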